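Swapping nitro for trifluoromethyl on a dichloroacetamide

The compounds below may be only part of what the source reports. "The series", "measured", "known", "first", "only" and "open" are said of these compounds alone.

Measured compounds:
- compound 1, `O=C(Nc1cccc(Cl)c1)C(Cl)Cl` — in a functional assay on BGC-823 cells (Homo sapiens) for antiproliferative activity, read by MTT assay, with a stated time of 72 h (a lower number here means a stronger inhibitor, a higher number a weaker inhibitor), compound 1 gives "not determined" (no result reported)
- compound 2, `O=C(Nc1cccc([N+](=O)[O-])c1)C(Cl)Cl` — 123000 nM

For the measured compounds named here, compound 2 is the only compound here with a number in this assay, so there is nothing to rank it against; its value of 123000 nM simply marks a weak inhibitor, and compound 1 gives no number at all. The next compound, compound 3, `O=C(Nc1cccc(C(F)(F)F)c1)C(Cl)Cl`, keeps the shared core of compound 2 and changes one group: trifluoromethyl in place of nitro on an aromatic carbon. Going by the values given here, no measured pair in this set shows what such an exchange does in this assay, so the size and direction of the step from compound 2 to compound 3 cannot be read from the data; the cautious expectation is a step no larger than the usual scatter, in either direction. On that basis compound 3 is estimated at 100000 nM, with a range from 30000 nM to 400000 nM, which means an expected step of a 1.2-fold lower number from compound 2 to compound 3 (0.09 log units; within the scatter) relative to compound 2.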

Compound 3, half-maximal inhibitory concentration: 143000 nM
Beside the measured number, compound 3's estimate is 1.4-fold (0.16 log units) below it; the measured number falls inside the stated range.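

For the compounds shown here, putting trifluoromethyl in place of nitro on this aromatic carbon gives a 1.2-fold higher number from compound 2 to compound 3 (0.07 log units; within the scatter) in this assay, and this is the first step at this position that can be read at all. Nitro carries hydrogen-bond acceptors and trifluoromethyl carries none, yet for this one pair the exchange moves the number by no more than repeated measurements normally would, and both compounds stay in the range of weak inhibitors. Nothing is available that would explain this outcome.

Compound 1, with chlorine at the same place, has no number, so any step to or from it cannot be read. Going by these compounds, two compounds with numbers cannot show whether this position ever matters, so it stays open whether an amine, a carboxylic acid or a longer chain on this aromatic carbon would give a value clearly apart from these, and whether a change elsewhere on the shared core would do so.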